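Chlorophenyl in place of trimethylphenyl on the sulfur

A few compounds are considered here, and "the series" means these few. Any claim that something is new, unique, unknown or untested is made for them only; others in the source may bear on it.

Compound 1 `Nc1ncnc2c1ncn2[C@@H]1O[C@H](COCCOCCNc2ncnc3c2ncn3[C@@H]2O[C@H](CO)[C@@H](O)[C@H]2O)[C@@H](O)[C@H]1O`: 912000 nM
Compound 2 `Cc1cc(C)c(SCc2ncnc3c2ncn3[C@@H]2O[C@H](CO)[C@@H](O)[C@H]2O)c(C)c1`: 33100 nM

In an assay on isolated protein for binding affinity to Equilibrative nucleoside transporter 1 (Homo sapiens) (a higher number here means a weaker inhibitor, a lower number a stronger inhibitor), compound 2 has the lower of the two numbers, and compound 1 sits far higher, well beyond the scatter. Compound 3 `OC[C@H]1O[C@@H](n2cnc3c(CSc4cccc(Cl)c4)ncnc32)[C@H](O)[C@@H]1O` differs from compound 2 in one place: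
3-chlorophenyl in place of 2,4,6-trimethylphenyl on a sulfur
Going by the values given here, no step between two measured compounds shows such an exchange, so its size is unknown. The step from compound 2 to compound 3 is expected to be a 1.1-fold lower number from compound 2 to compound 3 (0.04 log units; within the scatter), hardly more than the scatter. For compound 3 an inhibitory concentration of about 30000 nM is estimated, between 8000 nM and 120000 nM.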

Compound 3, half-maximal inhibitory concentration: 282 nM
The estimate for compound 3 lay 110-fold (2.03 log units) above the measured number; measured number outside the range, below it.
By their numbers in this assay, from the lowest: compound 3; then compound 2; then compound 1.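

In this assay, the aryl group on the sulfur turns out to matter strongly: 3-chlorophenyl in place of 2,4,6-trimethylphenyl gives a 120-fold lower number from compound 2 to compound 3 (2.07 log units; beyond the scatter) and shows that this position responds to a single exchange, which the two earlier compounds, differing in more than one place, could not reveal. Nothing measured here accounts for the size of this step. Going by these compounds, the exchange adds the chlorine and removes the methyl groups together, and which of these carries the step stays open. On these data alone, whether a 3-methoxyphenyl or a benzyl group on the sulfur would hold the lower number is also open.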